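A few compounds are considered here, and "the series" means these few. Any claim that something is new, unique, unknown or untested is made for them only; others in the source may bear on it.

Working notes on the series. The shared core carries a varied group on a saturated chain carbon bound to a carbonyl carbon. Compound 1 `CC(C)[C@H](NC(=O)COc1cccc2ccccc12)C(=O)N[C@@H](CC(=O)O)C(=O)COc1cc(C(F)(F)F)n(C)n1` gives 46000 nM in a functional assay on Jurkat cells (Homo sapiens) for inhibition; a lower number here means a stronger inhibitor, a higher number a weaker inhibitor; compound 2 `COC(=O)c1cc(OCC(=O)[C@H](CC(=O)O)NC(=O)[C@@H](NC(=O)COc2cccc3ccccc23)C(C)C)no1` gives 71000 nM; compound 3 `CC(C)[C@H](NC(=O)COc1cccc2ccccc12)C(=O)N[C@@H](CC(=O)O)C(=O)CSc1nc(-c2ccccc2)no1` gives 102000 nM, the highest of the three numbers, its gap to compound 2 within the scatter and its gap to compound 1 beyond it, as a 2.2-fold higher number from compound 1 to compound 3 (0.35 log units; beyond the scatter) and a 1.4-fold higher number from compound 2 to compound 3 (0.16 log units; within the scatter) show. Compound 4 `CC(C)[C@H](NC(=O)COc1cccc2ccccc12)C(=O)N[C@@H](CC(=O)O)C(=O)COc1nc2ccccc2[nH]1` differs from compound 3 at the same place: (1H-benzimidazol-2-yl)oxy in place of (3-phenyl-1,2,4-oxadiazol-5-yl)sulfanyl on a saturated chain carbon bound to a carbonyl carbon. Both earlier steps at this position were small, so only a modest move is expected, if any, toward the lower numbers of compounds 1 and 2. Compound 4 is therefore estimated at 60000 nM, range 25000 nM to 140000 nM, an expected step of a 1.7-fold lower number from compound 3 to compound 4 (0.23 log units; within the scatter).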

Compound 4, half-maximal inhibitory concentration: > 200000 nM
Compound 4: no number, only a limit; the forecaster's own chance of this, stated with the estimate: 10%; middle value at least 3.3-fold (0.52 log units) away from the limit.
By their numbers in this assay, from the lowest: compounds 1, 2 and 3 (each within the scatter of the next, the first and the last beyond it). At a limit, above all of these: compound 4.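

Compound 4 gives no number in this assay, only a limit: the limit of > 200000 nM in this assay, at which 1 of the 4 values shown sits.

Among these compounds, this position therefore tolerates less than the earlier compounds suggested: an at least 4.3-fold higher number from compound 1 to compound 4 (0.63 log units; beyond the scatter) and an at least 2.8-fold higher number from compound 2 to compound 4 (0.44 log units; beyond the scatter) both exceed every step among compounds 1, 2 and 3. Against compound 3 the separation is not established, since an at least 1.9-fold higher number from compound 3 to compound 4 (0.29 log units; that floor lies within the scatter) has a floor within the scatter.

Open is whether the oxygen link or the ring hydrogen on nitrogen matters: neither (1H-benzimidazol-2-yl)sulfanyl nor (1-methyl-1H-benzimidazol-2-yl)oxy appears among the compounds shown.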